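Replacing a Methyl with Hydrogen on Compound 1

A few compounds are considered here, and "the series" means these few. Any claim that something is new, unique, unknown or untested is made for them only; others in the source may bear on it.

compound 1 `Cc1ccc(-c2ccsc2S(=O)(=O)NCCNC(=O)Nc2cc(C(F)(F)F)cc(C(F)(F)F)c2)c(Oc2ccc(O)c(O)c2)c1` gives 5600 nM here
compound 2 `CC(C)c1ccc(Oc2ccc(O)c(O)c2)c(-c2ccsc2S(=O)(=O)NCCNC(=O)Nc2cc(Cl)cc(Cl)c2)c1` gives 6400 nM here

In a functional assay on RS4-11 cells (Homo sapiens) for inhibition, read by CCK-8 assay, with a stated time of 48 h (on this read-out lower numbers stand for stronger inhibition and higher numbers for weaker inhibition), compound 1 gives 5600 nM and compound 2 gives 6400 nM, two values that lie within the scatter of each other. Among the measured compounds shown here, compound 1 therefore stands level with the only other measured compound, and both are in the micromolar range.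

Compound 3 `O=C(NCCNS(=O)(=O)c1sccc1-c1ccccc1Oc1ccc(O)c(O)c1)Nc1cc(C(F)(F)F)cc(C(F)(F)F)c1` has not yet been measured. It carries hydrogen in place of methyl on an aromatic carbon, meta to a 3,4-dihydroxyphenoxy group and para to a large group hydrogen in place of methyl on an aromatic carbon in the account of how it differs from compound 1. For the measured compounds named here, no measured pair shows what this change does, so no step beyond the scatter is expected in this assay. The expected step of a 1.1-fold higher number from compound 1 to compound 3 (0.03 log units; within the scatter) is small, and its direction is open. Compound 3 is estimated at 6000 nM, within a range of 2800 nM to 13000 nM.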

Compound 3, half-maximal inhibitory concentration: 4900 nM
For compound 3 the middle estimate is 1.2-fold (0.09 log units) above the measured one, and the stated range covers the measured number.
By their numbers in this assay, from the lowest: compounds 3, 1 and 2 (each within the scatter of the next).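

In this assay, among the compounds shown here, hydrogen in place of methyl on an aromatic carbon, meta to a 3,4-dihydroxyphenoxy group and para to a large group, gives a 1.1-fold lower number from compound 1 to compound 3 (0.06 log units; within the scatter) and so provides the first measured pair at this position. On this pair the methyl group is not needed to keep the micromolar level of compound 1, since compound 3 stands level with it without that group. No further data bear on why this position accepts the change.

As far as these compounds go, only hydrogen and methyl are compared at this position, so what a methoxy group, a chlorine atom or an amine would do there remains open. A single pair also cannot say whether the result would hold on a different background, for instance with a carboxylic acid in place of the trifluoromethyl groups.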